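The compounds below may be only part of what the source reports. "The series", "measured", "known", "first", "only" and "open" are said of these compounds alone.

Working notes on the series. In an ADME assay on microsomes from liver (Homo sapiens) for metabolic stability, read by LC-MS, with NADPH named in the record, with a stated time of 60 min, tested at 1 uM, in the absence of a further agent (a lower number here means that less of the compound is left, a higher number that more of the compound is left), compound 1 (`COc1ccc(-c2c(C)sc3c(N4CC[C@@H](NC(C)=O)C4)nc(C)nc23)cc1OC`) gives > 95% as a limit of the assay and not a number. Compound 2 (`CC(=O)N[C@@H]1CCN(c2cc(C)nn3c(-c4ccco4)c(C)nc23)C1`) gives > 95% as a limit too. Compound 3 (`COc1ccc(-c2c(C)nc3c(N4CC[C@@H](NC(=O)c5ccccc5)C4)cc(C)nn23)cc1OC`) also gives only a limit, > 95% in this case, so it has no exact number of its own. The series as measured so far stands at the limit of > 95% in this assay, at which 3 of the 3 values shown sit, and offers no ordering of the three compounds.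

Compound 4 (`COc1ccc(-c2c(C)nc3c(N4CC[C@@H](NC(=O)OC5CCCCC5)C4)cc(C)nn23)cc1OC`) keeps the core of compound 3 and changes one place, with cyclohexyloxy in place of phenyl on a carbonyl carbon. Cut one bond further out, this is benzamido to (cyclohexyloxycarbonyl)amino.

Within the data shown here, no two measured compounds differ in one place, so no measured step sizes this change, and no measured compound carries the entering group. The expectation in this assay is therefore a judgement on the change alone: a moderate move to less compound remaining, with no move beyond the scatter still possible. The estimated step is a number at least 13 percentage points lower from compound 3 to compound 4 (beyond the scatter) and it counts compound 3 at its limit. For compound 4 the expected value is 82% with an estimated range from 55% to 98% and a result at the limit remains possible.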

Compound 4, percent of the compound remaining: > 95%
Compound 4: a limit, no number; the forecaster's own chance of this, stated with the estimate: 35%; middle value at least 13 percentage points from the limit.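

In this assay compound 4 gives > 95%, a limit of the assay and not a number. Among these compounds, compound 3 also stands at a limit, so no step from one to the other can be read. The compounds shown leave open any ordering within the series and the size of any effect of cyclohexyloxy in place of phenyl on a carbonyl carbon, as all results stand at one limit: the limit of > 95% in this assay, at which 4 of the 4 values shown sit.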